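This account rests on a few compounds, and the source may have more. Where it says the series, first, only, none or still open, it means among the compounds named here.

- compound 1 `OC[C@H]1O[C@@H](n2cnc3c(NCc4ccc(Cl)cc4)ncnc32)[C@H](O)[C@@H]1O`: > 166000 nM
- compound 2 `OC[C@H]1O[C@@H](n2cnc3c(NCc4ccc(F)c(F)c4F)ncnc32)[C@H](O)[C@@H]1O`: > 166000 nM
- compound 3 `OC[C@H]1O[C@@H](n2cnc3c(NCc4ccc(F)cc4Cl)ncnc32)[C@H](O)[C@@H]1O`: > 166000 nM

All three entries come from a functional assay on MCF cells (Homo sapiens) for antiproliferative activity, with a stated time of 72 h (on this read-out higher numbers stand for weaker inhibition and lower numbers for stronger inhibition), and each is a limit of the assay rather than a number. The set as a whole shows (the limit of > 166000 nM in this assay, at which 3 of the 3 values shown sit). Compound 3 therefore has no exact position, and compound 3 is recorded only as > 166000 nM.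

Compound 4 `OC[C@H]1O[C@@H](n2cnc3c(NCc4ccccc4OC(F)F)ncnc32)[C@H](O)[C@@H]1O` keeps the shared core and changes one group: 2-(difluoromethoxy)phenyl in place of 2-chloro-4-fluorophenyl on a saturated chain carbon bound to a nitrogen on an aromatic ring. In words, 2-(difluoromethoxy)phenyl takes the place of 2-chloro-4-fluorophenyl on a saturated chain carbon bound to a nitrogen on an aromatic ring.

Three measured swaps at this same place bear on the new change: a step that the two limits leave unreadable from compound 1 to compound 3, a step that the two limits leave unreadable from compound 2 to compound 3 and a step that the two limits leave unreadable from compound 1 to compound 2. None of them has a size that can be read, so they give no direction. What they do show is that three different groups here all ended at the limit. On that basis, no shift beyond the scatter is expected in this assay, and another limit is the likeliest report.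

The expected change is a step that the limit leaves unreadable from compound 3 to compound 4.

For compound 4 the estimate is 170000 nM, with an expected range from 80000 nM to 300000 nM.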

Compound 4, half-maximal inhibitory concentration: > 166000 nM
Compound 4 gave a limit, no number; the forecaster's own chance of this, stated with the estimate: 85%; the middle value is on the limit's open side.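

Compound 4 is reported in this assay only as a limit, just as compound 1, compound 2 and compound 3 are, so none of its steps from those three compounds can be read. All four compounds share one recorded result: the limit of > 166000 nM in this assay, at which 4 of the 4 values shown sit.

The compounds shown leave open whether any group at this place gives a measurable value in this assay, and how these four groups rank against one another.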